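The source may hold more compounds than are shown below. What is called first, only, known or untested is meant among the compounds shown, and "the series" means these compounds.

- compound 1 `COc1ccc2c(c1)nc(/C=C/C(=O)/C=C/c1ccc(O)c(OC)c1)n2C`: 4800 nM
- compound 2 `COc1ccc(/C=C/C(=O)/C=C/c2nc3cc(C)ccc3n2C)cc1O`: 4800 nM

In a functional assay on SH-SY5Y cells (Homo sapiens) for cytotoxicity, read by MTT assay, with a stated time of 48 h (on this read-out lower numbers stand for stronger inhibition and higher numbers for weaker inhibition), compound 2 gives 4800 nM, level with compound 1 at 4800 nM, within the usual scatter. Compound 3 `COc1ccc2c(c1)nc(/C=C/C(=O)/C=C/c1ccc(OC)c(O)c1)n2C`, not yet measured, differs from compound 2 by a single swap, methoxy in place of methyl on an aromatic carbon. Going by the values given here, no measured pair shows this swap alone, so the only guides are compound 1 at 4800 nM and compound 2 at 4800 nM. The expected step of a 1.1-fold lower number from compound 2 to compound 3 (0.03 log units; within the scatter) is estimated to stay within the scatter, with no direction favoured. Compound 3 is expected at 4500 nM, with an estimated range of 2000 nM to 10000 nM.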

Compound 3, half-maximal inhibitory concentration: 4800 nM
Beside the measured number, compound 3's estimate is 1.1-fold (0.03 log units) below it, within the range that was stated.
By their numbers in this assay, from the lowest: compounds 1, 2 and 3 (each within the scatter of the next).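

Going by these compounds alone, two single changes can now be read for the first time. In this assay, methoxy in place of methyl on an aromatic carbon gives no change at the digits printed from compound 2 to compound 3 (within the scatter), and 3-hydroxy-4-methoxyphenyl in place of 4-hydroxy-3-methoxyphenyl gives no change at the digits printed from compound 1 to compound 3 (within the scatter), so neither swap separates these compounds on this read-out. No supporting measurement is available to explain this result. On these data alone, whether an amine or a carboxylic acid on that aromatic carbon would shift the number remains open. So does the effect of a longer chain there.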